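The compounds below may be only part of what the source reports. "The series", "measured", "known", "first", "only" and "open" are said of these compounds alone.

Measured compounds:
compound 1 `CCCc1nc(-c2ccccc2)c(CNCCN2CCN(c3cccc(C)c3)CC2)o1`, 43.1%
compound 2 `CCCc1nc(-c2ccccc2)c(CNCCCN2CCN(c3ccc(F)cc3)CC2)o1`, 62.5%
compound 3 `CCCc1nc(-c2ccccc2)c(CNCCN2CCN(c3cccc(F)c3)CC2)o1`, 62.3%

In an assay on HEK293 cells for inhibition of Voltage-dependent T-type calcium channel subunit alpha-1G (Homo sapiens), read by fluorescence, tested at 10 uM (on this read-out lower numbers stand for less inhibition and higher numbers for more inhibition at the one concentration tested (going by the name of the read-out)), compound 2 stands alongside compound 3, the two values being within the scatter of each other, while both stand beyond compound 1. Compound 4 `CCCc1nc(-c2ccccc2)c(CNCCCN2CCN(c3ccccc3C)CC2)o1` differs from compound 2 by 2-methylphenyl in place of 4-fluorophenyl on an amine nitrogen in a ring. Within the data shown here, the one measured step that bears on this is a number 19.2 percentage points higher from compound 1 to compound 3 (beyond the scatter), which runs in the opposite direction, fluoro replacing methyl. The present change puts methyl back in place of fluoro, though on a differently named phenyl, so a drop of modest size is expected, a number 15.5 percentage points lower from compound 2 to compound 4 (beyond the scatter). Compound 4 is therefore estimated at 47%, in a range from 28% to 64%.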

Compound 4, a percentage reported as inhibition, at one concentration (the size of the read-out at that concentration, not a potency): 54.5%
Compound 4: middle estimate off by 7.5 percentage points, on the low side; measured number inside the range.
By their numbers in this assay, from the lowest: compound 1; then compounds 4, 3 and 2 (each within the scatter of the next).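

In this assay, 2-methylphenyl in place of 4-fluorophenyl on the amine nitrogen in a ring gives a number 8 percentage points lower from compound 2 to compound 4 (within the scatter). This exchange therefore leaves the read-out within the scatter, unlike the other listed exchange between these substituents, a number 19.2 percentage points higher from compound 1 to compound 3 (beyond the scatter), which lies beyond it. Nothing available here accounts for this difference.

On these data alone, this single step changes both the substituent and its named place on the phenyl, so the contribution of each remains open. Also open, as far as these compounds go, is how a methoxy group or a nitrile on that phenyl would read.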